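This account rests on a few compounds, and the source may have more. Where it says the series, first, only, none or still open, it means among the compounds named here.

Compound 1 `O=C(O)c1cc2ccc(-c3ccc(Cl)cc3)cc2n1O`: > 100000 nM
Compound 2 `O=C(O)c1cc2ccc(-c3ccc(C(F)(F)F)cc3)cc2n1O`: 68000 nM
Compound 3 `O=C(O)c1cc2ccc(-c3ccc(OC(F)(F)F)cc3)cc2n1O`: > 100000 nM

In an ADME assay on HS27 cells (Homo sapiens) for antiproliferative activity, read by sulforhodamine B assay, with a stated time of 48 h (on this read-out higher numbers stand for weaker inhibition and lower numbers for stronger inhibition), compound 3 gives only a limit, > 100000 nM, and not a number. The series is bounded by the limit of > 100000 nM in this assay, at which 2 of the 3 values shown sit.

Compound 4 `COc1ccc(-c2ccc3cc(C(=O)O)n(O)c3c2)cc1` differs from compound 3 in one group: methyl in place of trifluoromethyl on an oxygen on an aromatic ring. In words, trifluoromethoxy becomes methoxy.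

Three measured swaps of the group on an aromatic carbon bear on this change, though only loosely: an at least 1.4-fold lower number from compound 1 to compound 2 (0.16 log units; that floor lies within the scatter), an at least 1.4-fold higher number from compound 2 to compound 3 (0.16 log units; that floor lies within the scatter) and a step that the two limits leave unreadable from compound 1 to compound 3. From these small or unreadable steps, no step beyond the scatter is expected in this assay, in either direction. The expected change is a number no higher from compound 3 to compound 4 (the limit leaves the size open). Compound 4 is estimated at 100000 nM, with an expected range of 45000 nM to 220000 nM.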

Compound 4, half-maximal inhibitory concentration: > 100000 nM
Compound 4: only a limit was reported; the forecaster's own chance of this, stated with the estimate: 65%; the middle value lies on the limit itself.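

In this assay compound 4 gives > 100000 nM, which is a limit and not a number. Within the data shown here, the one readable step is an at least 1.4-fold higher number from compound 2 to compound 4 (0.16 log units; that floor lies within the scatter), so methoxy is not separated from trifluoromethyl here. The steps to compound 4 from compound 1 and compound 3 cannot be read, and only compound 2 has a number, which leaves the series mostly at one limit: the limit of > 100000 nM in this assay, at which 3 of the 4 values shown sit.

From the compounds shown here alone, whether trifluoromethoxy to methoxy changes anything in this assay therefore stays open. So does whether an amine or a carboxylic acid in place of the methoxy would give a number in this assay.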